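From a Limit Value Toward a Measurable Amide Analogue

The source may report more compounds than this note shows. Statements on the series, on what has been measured and on what is new or still open speak of the compounds shown alone.

Compound 3 `O=C(Nc1cc(-c2ccccc2)nn1-c1ccccc1)c1ccccc1O` is the weakest member of the set shown: in an assay on isolated protein with metabotropic glutamate receptor 5 (Rattus norvegicus) as the target (a higher number here means that more compound is needed for the effect, a lower number that less compound is needed), compound 3 gives > 10000 nM, which is a limit of the assay rather than a number, (the limit of > 10000 nM in this assay, at which 1 of the 3 values shown sits). Compound 1 `O=C(Nc1cc(-c2ccccc2)nn1-c1ccccc1)c1ccc(F)cc1` gives 50 nM in this assay, and compound 2 `O=C(Nc1cc(-c2ccccc2)nn1-c1ccccc1)c1cnccn1` gives 400 nM. For the measured compounds named here, the steps that bear on the planned change are an at least 200-fold higher number from compound 1 to compound 3 (2.30 log units; beyond the scatter) and an at least 25-fold higher number from compound 2 to compound 3 (1.39 log units; beyond the scatter), both large; the smaller step of an 8.0-fold higher number from compound 1 to compound 2 (0.90 log units; beyond the scatter) shows that the other aryl amides remain measurable. Compound 4 `Cc1cccc(C(=O)Nc2cc(-c3ccccc3)nn2-c2ccccc2)c1` differs from compound 3 by 3-methylphenyl in place of 2-hydroxyphenyl on a carbonyl carbon. Undoing the entry of 2-hydroxyphenyl is expected to bring the number down by a large margin, an at least 100-fold lower number from compound 3 to compound 4 (2.00 log units; beyond the scatter). Compound 4 is therefore estimated at 100 nM, within 30 nM to 600 nM.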

Compound 4, half-maximal effective concentration: 100 nM
Beside the measured number, compound 4's estimate shows no gap at the digits printed, within the range that was stated.
By their numbers in this assay, from the lowest: compounds 1 and 4 (each within the scatter of the next); then compound 2. At a limit, above all of these: compound 3.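

In this assay, as far as these compounds go, the change to 3-methylphenyl on the carbonyl carbon restores a measurable value, with an at least 100-fold lower number from compound 3 to compound 4 (2.00 log units; beyond the scatter) as a step whose true size stays open, and compound 3 holds only a limit of the assay: the limit of > 10000 nM in this assay, at which 1 of the 4 values shown sits.

Compound 4 also shows a 4.0-fold lower number from compound 2 to compound 4 (0.60 log units; beyond the scatter) and, against the 4-fluorophenyl amide, a 2.0-fold higher number from compound 1 to compound 4 (0.30 log units; within the scatter) so the two cannot be separated.

Thus the sharp loss so far belongs to 2-hydroxyphenyl alone among these amides.

From the compounds shown here alone, whether that loss follows the hydroxyl itself or its place on the ring stays open. So does the effect of a methoxy group or an amine on that phenyl ring.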